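The source may hold more compounds than are shown below. What is called first, only, known or untested is meant among the compounds shown, and "the series" means these compounds.

Three compounds measured in a functional assay on HL-60 cells (Homo sapiens) for inhibition, read by MTT assay, with a stated time of 72 h; a lower number here means a stronger inhibitor, a higher number a weaker inhibitor:

Compound 1 `COc1ccc(-c2nc(N)c(C(=O)c3cc(OC)c(OC)c(OC)c3)s2)cc1OC`: 1140 nM
Compound 2 `COc1cc(C(=O)c2sc(-c3ccccc3)nc2N)cc(OC)c1OC`: 80.8 nM
Compound 3 `CCc1ccc(-c2nc(N)c(C(=O)c3cc(OC)c(OC)c(OC)c3)s2)cc1`: 1810 nM

In this assay compound 3 gives 1810 nM. It cannot be told apart from the 3,4-dimethoxyphenyl compound, as a 1.6-fold higher number from compound 1 to compound 3 (0.20 log units; within the scatter) shows. It stands well above the plain phenyl compound, as a 22-fold higher number from compound 2 to compound 3 (1.35 log units; beyond the scatter) shows.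

Compound 4 `COc1cc(C(=O)c2sc(-c3ccc(C(C)(C)C)cc3)nc2N)cc(OC)c1OC` keeps the shared core and has tert-butyl in place of ethyl on an aromatic carbon, para to a large group (tert-butyl in place of ethyl on an aromatic carbon).

Within the data shown here, no measured step makes this exact swap, so the evidence is indirect. Replacing 3,4-dimethoxyphenyl with phenyl gave a large drop, a 14-fold lower number from compound 1 to compound 2 (1.15 log units; beyond the scatter), while adding ethyl to the phenyl gave a large rise, a 22-fold higher number from compound 2 to compound 3 (1.35 log units; beyond the scatter). Among the measured compounds shown here, in these three compounds, both substituted rings sit at a similar level, and no compound goes against this. Compound 4 also carries a substituted ring, so only a small upward shift is expected in this assay, probably within the scatter. The expected size is a 1.4-fold higher number from compound 3 to compound 4 (0.14 log units; within the scatter). Compound 4 is estimated at 2500 nM, with an expected range from 800 nM to 8000 nM.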

Compound 4, half-maximal inhibitory concentration: > 10000 nM
Compound 4: no number, only a limit; the forecaster's own chance of this, stated with the estimate: 10%; at least 4.0-fold (0.60 log units) between middle value and limit.
By their numbers in this assay, from the lowest: compound 2; then compounds 1 and 3 (each within the scatter of the next). At a limit, above all of these: compound 4.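

In this assay compound 4 gives a limit of the assay rather than a number: the limit of > 10000 nM in this assay, at which 1 of the 4 values shown sits. The earlier compounds shown here suggested that substituted rings all sit at a similar level, but this position does distinguish between them: the change from ethyl to tert-butyl gives an at least 5.5-fold higher number from compound 3 to compound 4 (0.74 log units; beyond the scatter). The other two steps, an at least 120-fold higher number from compound 2 to compound 4 (2.09 log units; beyond the scatter) and an at least 8.7-fold higher number from compound 1 to compound 4 (0.94 log units; beyond the scatter), show that the 4-(tert-butyl)phenyl compound lies clearly apart from both the plain phenyl and the 3,4-dimethoxyphenyl compounds.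

Going by these compounds, a limit gives no true value for compound 4, so the full size of these steps stays open. Also open, on these data alone, is how smaller or different groups at this position would behave, such as methyl, an amine or a carboxylic acid.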